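Adding a Dimethylamino Group to the Benzyl Ring

The source may report more compounds than this note shows. Statements on the series, on what has been measured and on what is new or still open speak of the compounds shown alone.

Compound 3 `CCN(CCCCCCn1sc2cc(OC)c(OC)cc2c1=O)Cc1ccccc1` gives 20100 nM in an assay on isolated protein for inhibition of Amine oxidase [flavin-containing] B (Homo sapiens), read by fluorescence, with a stated time of 30 min (on this read-out higher numbers stand for weaker inhibition and lower numbers for stronger inhibition), the highest of the three numbers shown, though within the scatter of compound 1 `CCN(CCCCn1sc2cc(OC)c(OC)cc2c1=O)Cc1ccccc1OC` at 19400 nM and of compound 2 `COc1cc2sn(CCCCCCN(C)Cc3ccccc3)c(=O)c2cc1OC` at 13200 nM. Compound 4 `CCN(CCCCCCn1sc2cc(OC)c(OC)cc2c1=O)Cc1ccc(N(C)C)cc1` differs from compound 3 by dimethylamino in place of hydrogen on an aromatic carbon. Among the compounds with values here, the only single-place step measured, a 1.5-fold higher number from compound 2 to compound 3 (0.18 log units; within the scatter), concerns the chain amine rather than the benzyl group, so it bears only indirectly on this change. Compound 1 and compound 3 differ at two places, yet their numbers sit within the scatter of each other, suggesting that changes around this part of the molecule have so far moved little. The expected step is therefore a 1.1-fold lower number from compound 3 to compound 4 (0.05 log units; within the scatter), within the scatter. Compound 4 is estimated at 18000 nM in this assay, with a range from 7000 nM to 45000 nM.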

Compound 4, half-maximal inhibitory concentration: 12400 nM
Estimate against measurement, compound 4: 1.5-fold (0.16 log units) above; the range from low to high includes it.
By their numbers in this assay, from the lowest: compounds 4, 2, 1 and 3 (each within the scatter of the next).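

Within the data shown here, this is the first step measured on the benzyl ring itself. In this assay, the step is a 1.6-fold lower number from compound 3 to compound 4 (0.21 log units; within the scatter), so this aromatic carbon, para to a large group, accepts dimethylamino without a shift beyond the usual scatter. Nothing available explains this result.

From the compounds shown here alone, it remains open whether a carboxylic acid or a nitrile on the same aromatic carbon would give a step beyond the scatter. Going by these compounds, it is also open whether dimethylamino would give a similar step on a compound with a longer chain.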